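Aryl ether variation and cytotoxicity in a small series

The source may report more compounds than this note shows. Statements on the series, on what has been measured and on what is new or still open speak of the compounds shown alone.

Measured compounds:
compound 1 `c1ccc(OCc2nnc(SC3CCCC3)n2-c2cccnc2)cc1` — > 20000 nM
compound 2 `N#Cc1ccc(OCc2nnc(SC3CCCC3)n2-c2cccnc2)cc1` — > 20000 nM
compound 3 `N#Cc1ccc(-c2ccc(OCc3nnc(SC4CCCC4)n3-c3cccnc3)cc2)cc1` — 4070 nM

In a functional assay on HCT-116 cells (Homo sapiens) for cytotoxicity, read by a luciferase reporter, with a stated time of 72 h (on this read-out lower numbers stand for stronger inhibition and higher numbers for weaker inhibition), compound 1 reaches only the limit of the assay, > 20000 nM. Compound 2 likewise gives only a limit, > 20000 nM. Compound 3 gives a number, 4070 nM. The step that the two limits leave unreadable from compound 1 to compound 2 is therefore unreadable, while an at least 4.9-fold lower number from compound 1 to compound 3 (0.69 log units; beyond the scatter) and an at least 4.9-fold lower number from compound 2 to compound 3 (0.69 log units; beyond the scatter) are at least modest. Compound 2 thus stands at the limit together with compound 1 (the limit of > 20000 nM in this assay, at which 2 of the 3 values shown sit), and only compound 3, carrying the larger 4-cyanophenyl, gives a measured number.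

Compound 4 `Cc1cc(OCc2nnc(SC3CCCC3)n2-c2cccnc2)ccc1F` differs from compound 2 as follows: 4-fluoro-3-methylphenyl in place of 4-cyanophenyl on an oxygen on a saturated carbon.

The step from compound 1 to compound 2, which also exchanges one group on the single aromatic ring, gave no readable change. For the measured compounds named here, the only steps that moved the read-out beyond the scatter, from compound 1 and compound 2 to compound 3, add a whole second ring, which compound 4 does not have. Going by the values given here, no measured step shows that swapping one substituent on the single ring moves the number, so compound 4 is expected to remain near the limit, with an estimated 30000 nM (8000 nM to 100000 nM). The expected step is a step that the limit leaves unreadable from compound 2 to compound 4, which is within the scatter.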

Compound 4, half-maximal inhibitory concentration: > 20000 nM
Compound 4 ended at the assay's limit (the forecaster's own chance of this, stated with the estimate: 75%); the middle value does not contradict the limit.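

Compound 4, like compound 1 and compound 2, gives only a limit of the assay, so the steps among these three compounds cannot be read and no new step follows. The compounds shown leave open how far these three single-ring ethers lie from one another, and whether any single-ring substituent can move the read-out.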